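The compounds below may be only part of what the source reports. "The series", "measured", "known", "first", "only" and "open" are said of these compounds alone.

Results in an ADME assay on the whole organism (Rattus norvegicus, strain Sprague-Dawley) for pharmacokinetics, using cassette dosing, at a dose of 0.5 mg/kg by the intravenous route (a lower number here means slower removal, a higher number faster removal of the compound), for the compounds at hand

Compound 1 `O=C1Cc2cc(NC(=O)C(=O)N3CCN(c4ccc(Cl)cc4)CC3)ccc2N1` gives "not determined" (no result reported)
Compound 2 `O=C(Nc1ccc2[nH]c(=O)oc2c1)C(=O)N1CCN(c2ccccc2)CC1` gives "not determined" (no result reported)
Compound 3 `O=C(Nc1ccc2[nH]c(=O)oc2c1)C(=O)N1CCN(c2ccc(C(F)(F)F)cc2)CC1` gives 15.1 mL/min/kg

Of these three compounds, only compound 3 carries a number, at 15.1 mL/min/kg in this assay. Compound 1 and compound 2 have no result, so compound 3 cannot be ranked against either of them, and the series offers no internal comparison.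

The next compound to be measured is compound 4 `O=C(Nc1ccc2[nH]c(=O)oc2c1)C(=O)N1CCN(c2ccc(F)c(Cl)c2)CC1`. It keeps the shared core of compound 3 and differs in one place, where 3-chloro-4-fluorophenyl takes the place of 4-(trifluoromethyl)phenyl on an amine nitrogen in a ring: 3-chloro-4-fluorophenyl in place of 4-(trifluoromethyl)phenyl on an amine nitrogen in a ring. Both the group that leaves and the group that enters are a six-membered aromatic ring of carbon only, and neither carries a net charge.

Among the measured compounds shown here, no measured step between compounds that differ in one place is available to show how sensitive the read-out is to such a change. For the measured compounds named here, the only anchor is compound 3 at 15.1 mL/min/kg, and it gives no direction, so no step beyond the usual scatter is expected. The estimate amounts to a 1.2-fold higher number from compound 3 to compound 4 (0.08 log units; within the scatter), an expected step that stays inside that scatter. For compound 4 the estimated value is 18 mL/min/kg, with an expected range from 8 mL/min/kg to 38 mL/min/kg, and the measurement is still to come.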

Compound 4, clearance: 18.3 mL/min/kg
For compound 4 the middle estimate is 1.0-fold (0.01 log units) below the measured one; measured number inside the range.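

In this assay, among the compounds shown here, the change gives the first step that can be read at this place, on an amine nitrogen in a ring: a 1.2-fold higher number from compound 3 to compound 4 (0.08 log units; within the scatter). That step lies within the usual scatter, so 3-chloro-4-fluorophenyl and 4-(trifluoromethyl)phenyl cannot be told apart here, and this single pair shows that one substituted phenyl group can stand in for the other at this place without a step beyond the scatter. No measurement is available that would account for this result.

The two groups compared are both six-membered aromatic rings of carbon only without a net charge, so the compounds shown leave open whether the read-out would stay as it is with a pyridine ring, a carboxylic acid on the phenyl ring or a saturated ring such as cyclohexyl at this place. For the compounds shown here, they also leave open whether this insensitivity holds with a different group at the other end of the molecule, since compound 3 and compound 4 share the same core and are the only compounds with numbers.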